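Adding a second hydroxy to the hydrazone aryl of compound 1

This account rests on a few compounds, and the source may have more. Where it says the series, first, only, none or still open, it means among the compounds named here.

Compound 1 `O=C(N/N=C/c1ccccc1O)c1ccc(-c2nc3ccccc3s2)cc1` carries a 2-hydroxyphenyl on the carbon with a double bond to nitrogen, attached to the shared core. In an assay on isolated protein for inhibition of Maltase-glucoamylase (Homo sapiens), with a stated time of 15 min (on this read-out lower numbers stand for stronger inhibition and higher numbers for weaker inhibition), compound 1 gives 5550 nM, the lowest of the three numbers measured. Compound 2 `O=C(N/N=C/c1ccc([N+](=O)[O-])cc1)c1ccc(-c2nc3ccccc3s2)cc1` gives 26400 nM, and compound 3 `COc1ccc(/C=N/NC(=O)c2ccc(-c3nc4ccccc4s3)cc2)c(I)c1O` gives 44800 nM. The step of a 4.8-fold higher number from compound 1 to compound 2 (0.68 log units; beyond the scatter) and the step of an 8.1-fold higher number from compound 1 to compound 3 (0.91 log units; beyond the scatter) both lie beyond the scatter, while the step of a 1.7-fold higher number from compound 2 to compound 3 (0.23 log units; within the scatter) does not.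

Compound 4 `O=C(N/N=C/c1cc(O)ccc1O)c1ccc(-c2nc3ccccc3s2)cc1` differs from compound 1 in one place: hydroxy in place of hydrogen on an aromatic carbon. Cut one bond further out, the change reads 2-hydroxyphenyl to 2,5-dihydroxyphenyl, so the hydroxy group of compound 1 is kept and a second one enters.

Among the measured compounds shown here, no measured pair shows this change. The two steps from compound 1 both replace the whole 2-hydroxyphenyl and both give higher numbers, with compound 3 showing that a more substituted ring can read weaker, but neither keeps the hydroxy of compound 1 in place. For the measured compounds named here, with no direct precedent, the expected step of a 1.3-fold higher number from compound 1 to compound 4 (0.10 log units; within the scatter) is small, possibly within the scatter, with a lean toward a higher number. Compound 4 is therefore estimated at 7000 nM in this assay, with a range from 2500 nM to 20000 nM.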

Compound 4, half-maximal inhibitory concentration: 11900 nM
The estimate for compound 4 lay 1.7-fold (0.23 log units) below the measured number; low and high end bracket the measured number.
By their numbers in this assay, from the lowest: compound 1; then compound 4; then compounds 2 and 3 (each within the scatter of the next).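

In this assay, among the compounds shown here, the second hydroxy gives the first measured change that keeps the 2-hydroxyphenyl of compound 1 in place, and it still costs strength (a 2.1-fold higher number from compound 1 to compound 4 (0.33 log units; beyond the scatter)), so this ring carbon, meta to a large group and para to a hydroxy group, is not a neutral place for a hydroxy. The 2,5-dihydroxyphenyl nevertheless reads better than either whole-ring replacement (a 2.2-fold lower number from compound 2 to compound 4 (0.35 log units; beyond the scatter); a 3.8-fold lower number from compound 3 to compound 4 (0.58 log units; beyond the scatter)), which places compound 4 in the gap between compound 1 and the pair of compounds 2 and 3, and compound 1 remains the strongest of the four. No measured evidence accounts for the direction or the size of these steps.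

On these data alone, it remains open whether the higher number belongs to the hydroxy itself or to any added group at this carbon, as a methoxy, an amino group or a chlorine in the same place could show. As far as these compounds go, how much the hydroxy of compound 1 contributes also remains open, a question that an unsubstituted phenyl on the same core would address.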